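The compounds below may be only part of what the source reports. "The series", "measured", "known", "first", "only" and "open" are said of these compounds alone.

Compounds measured in a toxicity assay on A549 cells (Homo sapiens) for cytotoxicity, read by luminescence and CellTiter-Glo, with a stated time of 48 h; on this read-out lower numbers stand for higher toxicity in this test and higher numbers for lower toxicity in this test:

Compound 1, `CCNC(=O)CCCOc1ccc(-c2nc3ncccn3c2NC2CCCCC2)cc1`: > 100000 nM (a limit of this assay)
Compound 2, `COCCCCOc1ccc(-c2nc3ncccn3c2NC2CCCCC2)cc1`: 100000 nM
Compound 3, `Oc1ccc(-c2nc3ncccn3c2NC2CCCCC2)cc1`: > 100000 nM (a limit of this assay)

Compound 3 stands at a limit of this assay and not at a number. Compound 1 likewise sits at a limit, as the limit of > 100000 nM in this assay, at which 2 of the 3 values shown sit, records. Compound 2 alone gives a number, and it lies at the same figure as that limit. The step of a number no lower from compound 2 to compound 3 (the limit leaves the size open) therefore reads only as no lower, and a step that the two limits leave unreadable from compound 1 to compound 3 is left open by the two limits.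

Compound 4, `Cc1cc(Br)ccc1-c1nc2ncccn2c1NC1CCCCC1`, differs from compound 3 by 4-bromo-2-methylphenyl in place of 4-hydroxyphenyl on an aromatic carbon. The measured steps all concern the group on the oxygen on the aromatic ring, not the aryl ring itself, so they bear on this change only in showing that nothing in the series has moved off the top of the assay. No step beyond the scatter is expected in this assay; the estimate for compound 4 is 80000 nM, between 20000 nM and 200000 nM, which is the expected step of an at least 1.2-fold lower number from compound 3 to compound 4 (0.09 log units; that floor lies within the scatter).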

Compound 4, half-maximal cytotoxic concentration: 45000 nM
Compound 4: middle estimate off by 1.8-fold (0.25 log units), on the high side, within the range that was stated.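

Within the data shown here, the change on this aromatic carbon of the five-membered aromatic ring gives the first step in this assay that reads as beyond the scatter: 4-bromo-2-methylphenyl in place of 4-hydroxyphenyl gives an at least 2.2-fold lower number from compound 3 to compound 4 (0.34 log units; beyond the scatter). The earlier steps all concerned the group on the oxygen, and none of them had a readable size, so this is the first change shown to bring a measurable shift toward higher toxicity in this test. The size is only a floor because the starting point is a limit and not a number: the limit of > 100000 nM in this assay, at which 2 of the 4 values shown sit.

The compounds shown do not separate the bromine from the methyl, so it remains open whether 4-bromophenyl or 2-methylphenyl alone would carry the step. They also leave open how a 4-aminophenyl or 4-carboxyphenyl group at this place would read in this assay.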